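A few compounds are considered here, and "the series" means these few. Any claim that something is new, unique, unknown or untested is made for them only; others in the source may bear on it.

Working notes on the series in an assay on isolated protein for inhibition of tyrosine-protein kinase receptor UFO (Homo sapiens), read by FRET and Z'-LYTE, with a stated time of 1.5 h; a lower number here means a stronger inhibitor, a higher number a weaker inhibitor.

For the measured compounds named here, compound 3 `Cc1ccc2c(c1)c(=O)c(C(=O)Nc1ccc(Oc3ncnc4[nH]cc(-c5ccccc5)c34)c(F)c1)c(C)n2C` carries the only number among the three measured compounds: in this assay compound 3 gives 100 nM. Compound 1 `Cc1c(C(=O)Nc2ccc(Oc3ncnc4[nH]cc(-c5ccccc5)c34)c(F)c2)c(=O)c2ccccc2n1C` sits at a limit of the assay, where compound 1 gives > 10000 nM. Compound 2 `Cc1c(C(=O)Nc2ccc(Oc3ncnc4[nH]cc(-c5ccccc5)c34)c(F)c2)c(=O)c2cc(F)ccc2n1C` sits at the same limit, and compound 2 gives > 10000 nM. The steps read an at least 100-fold lower number from compound 1 to compound 3 (2.00 log units; beyond the scatter) and an at least 100-fold lower number from compound 2 to compound 3 (2.00 log units; beyond the scatter), while a step that the two limits leave unreadable from compound 1 to compound 2 stays unreadable, since two of the three values rest on (the limit of > 10000 nM in this assay, at which 2 of the 3 values shown sit).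

Compound 4 `CCc1ccc2c(c1)c(=O)c(C(=O)Nc1ccc(Oc3ncnc4[nH]cc(-c5ccccc5)c34)c(F)c1)c(C)n2C` differs from compound 3 by methyl in place of hydrogen on a saturated chain carbon bound to an aromatic carbon. The measured steps concern hydrogen to methyl, or fluoro to methyl, on an aromatic carbon; none of them covers growing that methyl into an ethyl. With the hydrogen-to-methyl step already made, the further step to ethyl is expected to be a 1.2-fold higher number from compound 3 to compound 4 (0.08 log units; within the scatter), i.e. a change within the scatter. Compound 4 is therefore estimated at 120 nM, within 40 nM to 400 nM.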

Compound 4, half-maximal inhibitory concentration: 6 nM
Estimate against measurement, compound 4: 20-fold (1.30 log units) above; measured number below the stated range.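

In this assay, extending the methyl to an ethyl gives a 17-fold lower number from compound 3 to compound 4 (1.22 log units; beyond the scatter), so this place still responds to a single added carbon after the earlier hydrogen-to-methyl step. Measured against hydrogen at the same place, ethyl gives an at least 1600-fold lower number from compound 1 to compound 4 (3.22 log units; beyond the scatter), and measured against fluoro it gives an at least 1600-fold lower number from compound 2 to compound 4 (3.22 log units; beyond the scatter). Both of these larger steps start from a limit of the assay, so their true size cannot be read: the limit of > 10000 nM in this assay, at which 2 of the 4 values shown sit.

The compounds shown leave open whether the trend continues to a propyl or a longer chain or ends at ethyl. They also leave open whether a branched isopropyl, a methoxy or an amine at this place would match the ethyl of compound 4.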